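This account rests on a few compounds, and the source may have more. Where it says the series, first, only, none or still open, it means among the compounds named here.

In a functional assay on DU-145 cells (Homo sapiens) for inhibition, read by trypan blue exclusion, with a stated time of 96 h (on this read-out lower numbers stand for stronger inhibition of growth and higher numbers for weaker inhibition of growth), compound 2 (`COc1ccc(/C=C(\C(=O)c2ccc(Br)cc2)S(=O)(=O)c2ccc(Br)cc2)cc1`) gives 25000 nM and sits at the top of the three measured numbers. Compound 1 (`O=C(/C(=C\c1ccc(F)c([N+](=O)[O-])c1)S(=O)(=O)c1ccc(Br)cc1)c1ccc(Br)cc1`) gives 25000 nM and shares that place at the digits shown. Compound 3 (`O=C(/C(=C\c1csc([N+](=O)[O-])c1)S(=O)(=O)c1ccc(Br)cc1)c1ccc(Br)cc1`) gives 1000 nM and lies furthest off. The two steps that reach it are large, a 25-fold lower number from compound 1 to compound 3 (1.40 log units; beyond the scatter) and a 25-fold lower number from compound 2 to compound 3 (1.40 log units; beyond the scatter) as measured.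

Compound 4 (`O=C(/C(=C\c1ccc(OC(F)(F)F)cc1)S(=O)(=O)c1ccc(Br)cc1)c1ccc(Br)cc1`) is still unmeasured and differs from compound 2 by a single change, trifluoromethyl in place of methyl on an oxygen on an aromatic ring in all, with trifluoromethyl in place of methyl on an oxygen on an aromatic ring. Within the data shown here, no measured step makes this exchange. Both large steps bring in the 5-nitrothiophen-3-yl group, which compound 4 lacks. The remaining step, 4-methoxyphenyl in place of 4-fluoro-3-nitrophenyl, reads no change at the digits printed from compound 1 to compound 2 (within the scatter) and is the closer guide. No step beyond the scatter is therefore expected, and the estimated step is a 1.3-fold lower number from compound 2 to compound 4 (0.10 log units; within the scatter) in this assay for now. Compound 4 is estimated at 20000 nM with 5000 nM to 50000 nM as the expected range.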

Compound 4, concentration for 50% growth inhibition: 25000 nM
The estimate for compound 4 lay 1.3-fold (0.10 log units) below the measured number, within the range that was stated.
By their numbers in this assay, from the lowest: compound 3; then compounds 1, 2 and 4 (each within the scatter of the next).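

In this assay, among these compounds, the first direct reading of a change at this oxygen on the aromatic ring, methoxy to trifluoromethoxy, gives no change at the digits printed from compound 2 to compound 4 (within the scatter). Among the compounds shown, the exchange of methyl for trifluoromethyl, with its larger heavy-atom count, therefore gives no separation from compound 2 in this read-out. Nothing available bears on the reason for this result.

The compounds shown leave open what an amine, a hydroxyl group or a longer chain such as ethoxy would give in place of the methoxy of compound 2. They also leave open how much of the distance to compound 3, at 1000 nM, belongs to the thiophene ring and how much to its nitro group.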